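The compounds below may be only part of what the source reports. "The series", "measured", "known", "first", "only" and "open" are said of these compounds alone.

The three measured compounds share a core that carries a nitro group and a trifluoromethyl group, and they are read in an ADME assay on Vero cells (Chlorocebus sabaeus) for cytotoxicity, read by MTT assay, with a stated time of 48 h; on this read-out higher numbers stand for weaker inhibition and lower numbers for stronger inhibition. Compound 1, `O=c1nc(NCc2cccc(F)c2)oc2c([N+](=O)[O-])cc(C(F)(F)F)cc12`, carries a 3-fluorophenyl group on a saturated chain carbon bound to a nitrogen on an aromatic ring. In this assay compound 1 gives only a limit, > 64 ug/mL. Compound 2, `O=c1cc(NCc2cccc(F)c2)sc2c([N+](=O)[O-])cc(C(F)(F)F)cc12`, differs from compound 1 in its core. In this assay compound 2 also gives only a limit, > 64 ug/mL. Among the measured compounds shown here, compound 3, `O=c1nc(NCC2CCCCC2)oc2c([N+](=O)[O-])cc(C(F)(F)F)cc12`, carries a cyclohexyl group in that place, and in this assay compound 3 gives 29.7 ug/mL, the only real number among the three, since (the limit of > 64 ug/mL in this assay, at which 2 of the 3 values shown sit).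

For the measured compounds named here, the step of an at least 2.1-fold lower number from compound 1 to compound 3 (0.33 log units; beyond the scatter) is the only measured step, and it runs from a limit to a number.

Compound 4, `O=c1nc(NCc2ccccc2)oc2c([N+](=O)[O-])cc(C(F)(F)F)cc12`, is not yet measured. It differs from compound 3 by phenyl in place of cyclohexyl on a saturated chain carbon bound to a nitrogen on an aromatic ring. Going by the values given here, this change runs close to the reverse of the one measured step, swapping the cyclohexyl back for an aromatic ring, so a higher number than compound 3 is expected for compound 4, quite possibly again reaching a limit. The estimated step of a 1.7-fold higher number from compound 3 to compound 4 (0.23 log units; within the scatter) reflects that expectation. For compound 4 in this assay the estimate is 50 ug/mL, with a range from 22 ug/mL to 110 ug/mL.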

Compound 4, half-maximal inhibitory concentration: 25.4 ug/mL
Beside the measured number, compound 4's estimate is 2.0-fold (0.29 log units) above it; the measured number falls inside the stated range.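

In this assay, a 1.2-fold lower number from compound 3 to compound 4 (0.07 log units; within the scatter) means that, on a saturated chain carbon bound to a nitrogen on an aromatic ring, phenyl and cyclohexyl cannot be told apart, so an aromatic ring in this place does not by itself return the reading to the limit. The change that does register is a smaller one, hydrogen in place of fluoro on an aromatic carbon, which gives an at least 2.5-fold lower number from compound 1 to compound 4 (0.40 log units; beyond the scatter). Among these compounds, then, it is the 3-fluorophenyl group of compound 1 that stands apart, not the cyclohexyl group of compound 3, although the true size of both steps from compound 1 stays unknown because compound 1 gives no real number: the limit of > 64 ug/mL in this assay, at which 2 of the 4 values shown sit.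

Going by these compounds, what remains open is whether other groups on the phenyl ring, such as a chloro, a methoxy or an amine, would behave like the fluoro or like hydrogen, and whether a longer chain in place of the benzyl group would change the reading. On these data alone, it is also open whether the core of compound 2, which sits at the same limit, would respond in the same way to losing the fluoro.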